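Amino in place of hydrogen on compound 2

This account rests on a few compounds, and the source may have more. Where it says the series, first, only, none or still open, it means among the compounds named here.

In a functional assay on Colon 26 cells (Homo sapiens) for cytotoxicity against Colon 26 (Mus musculus) (on this read-out lower numbers stand for stronger inhibition and higher numbers for weaker inhibition), compound 1 (`COc1ccc(-c2sc(NN)nc2-c2cc(OC)c(OC)c(OC)c2)cc1N`) gives 21.1 nM, and compound 2 (`COc1ccc(-c2nncn2-c2cc(OC)c(OC)c(OC)c2)cc1N`) gives 840 nM, the higher of the two numbers and beyond the scatter. Compound 3 (`COc1ccc(-c2nnc(N)n2-c2cc(OC)c(OC)c(OC)c2)cc1N`) has amino in place of hydrogen on an aromatic carbon of compound 2 (amino in place of hydrogen on an aromatic carbon). Among the compounds with values here, no measured pair shows this change, so the expectation is tentative and rests on compound 1 reaching 21.1 nM in this series. A move to a lower number, beyond the scatter, is expected: the estimated step is a 5.6-fold lower number from compound 2 to compound 3 (0.75 log units; beyond the scatter). For compound 3 the expected value is 150 nM, with an estimated range of 25 nM to 800 nM.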

Compound 3, half-maximal inhibitory concentration: > 3000 nM
Compound 3 was reported as a limit; the forecaster's own chance of this, stated with the estimate: 3%; middle value at least 20-fold (1.30 log units) from the limit.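

In this assay, amino on the aromatic carbon between two ring nitrogen atoms gives an at least 3.5-fold higher number from compound 2 to compound 3 (0.55 log units; beyond the scatter). Compound 3 stands as a limit: the limit of > 3000 nM in this assay, at which 1 of the 3 values shown sits. On this carbon of compound 2, hydrogen therefore gives the lower number, and amino does not improve on it.

From the compounds shown here alone, whether a methyl group, a chlorine atom or a methylamino group on this carbon would also raise the number stays open. A single pair also leaves open whether amino has the same effect on the core of compound 1.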